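Aminoamino to methylsulfanyl exchange: notes on four compounds

The compounds below may be only part of what the source reports. "The series", "measured", "known", "first", "only" and "open" are said of these compounds alone.

Measured so far:
Compound 1 `CN(C)c1ccc(-c2nc(NN)n(C)c(=O)c2C#N)cc1` gives 81 ug/mL in a functional assay, with a stated time of 20 min; on this read-out lower numbers stand for stronger inhibition and higher numbers for weaker inhibition.
Compound 2 `COc1cccc(-c2nc(NN)n(C)c(=O)c2C#N)c1OC` gives 44 ug/mL in this assay.
Compound 3 `COc1cccc(-c2nc(SC)n(C)c(=O)c2C#N)c1OC` gives 54 ug/mL in this assay.

Compound 2 and compound 3 differ in one place, (methylsulfanyl in place of aminoamino on an aromatic carbon). The step that this change made is a 1.2-fold higher number from compound 2 to compound 3 (0.09 log units; within the scatter), so the two compounds are not separated by the read-out. Compound 1 differs from compound 2 in more than one place; the difference between the two cores is not broken down here. The three measured numbers all lie within the usual scatter of one another, so no order among compound 1, compound 2 and compound 3 can be stated.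

Compound 4 `CSc1nc(-c2ccc(N(C)C)cc2)c(C#N)c(=O)n1C` is not yet measured. It stands to compound 1 as compound 3 stands to compound 2: methylsulfanyl in place of aminoamino on an aromatic carbon. This is the same kind of change, not the same change: around the place, compound 2 has the site meta to a large group, whereas compound 1 has it meta to a group of 9 heavy atoms.

Within the data shown here, the only measured instance of this change is a 1.2-fold higher number from compound 2 to compound 3 (0.09 log units; within the scatter). On that basis the step from compound 1 to compound 4 in this assay is expected to be a 1.2-fold higher number from compound 1 to compound 4 (0.07 log units; within the scatter), a small move that stays within the scatter. Compound 4 is accordingly estimated at 95 ug/mL, with a likely range from 50 ug/mL to 190 ug/mL.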

Compound 4, half-maximal inhibitory concentration: 78 ug/mL
The estimate for compound 4 lay 1.2-fold (0.09 log units) above the measured number, and the stated range covers the measured number.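

In this assay, methylsulfanyl in place of aminoamino on the core of compound 1 gives a 1.0-fold lower number from compound 1 to compound 4 (0.02 log units; within the scatter), so compound 1 and compound 4 are not separated by the read-out. Set beside the earlier instance, the change reads alike on the two cores: the same change on two cores in this assay, a 1.2-fold higher number (0.09 log units; within the scatter) from compound 2 to compound 3 and a 1.0-fold lower number (0.02 log units; within the scatter) from compound 1 to compound 4, 1.3-fold (0.11 log units) apart, within the scatter of two such steps. This shows that, on these two cores and in this one read-out, the exchange leaves the number within the scatter; it does not show that the same holds on any further core, and with neither step large, it gives no test of whether a step of real size would carry from one core to another.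

Going by these compounds, whether a different group on this aromatic carbon, such as a simple amine, a carboxylic acid or a longer alkylsulfanyl chain, would separate from aminoamino and methylsulfanyl remains open. Also open is whether the nitrile or the methyl group on the ring nitrogen contributes to these numbers, since both are shared by all the compounds shown.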